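Ring-nitrogen substituents and a flat series: toward compound 4

This account rests on a few compounds, and the source may have more. Where it says the series, first, only, none or still open, it means among the compounds named here.

Measured in a functional assay on NCI-H1975 cells (Homo sapiens) for inhibition, read by sulforhodamine B assay, tested at 10 uM; a higher number here means more inhibition at the concentration tested (going by the name of the read-out), a lower number less inhibition:
compound 1, `CN(C)c1ccc(C2CC(c3ccc(-n4ccnc4)cc3)=NN2)cc1`: 0.1%
compound 2, `CN(C)c1ccc(C2CC(c3ccc(-n4cncn4)cc3)=NN2S(C)(=O)=O)cc1`: -3.1%
compound 3, `C=C(C)C(=O)N1N=C(c2ccc(-n3ccnc3)cc2)CC1c1ccc(N(C)C)cc1`: -3.7%

On the bare numbers compound 3 has the smallest value of the three, but its gaps to compound 2 and to compound 1 both lie within the scatter, so the three compounds cannot be told apart on this read-out. For the measured compounds named here, the one step that can be isolated, a number 3.8 percentage points lower from compound 1 to compound 3 (within the scatter), places (1-methylethenyl)carbonyl in place of hydrogen on an amine nitrogen in a ring without moving the number beyond the scatter. Compound 2 differs from compound 1 in two places at once, so its value only shows a second substituent on that nitrogen giving the same near-zero level.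

Compound 4, `Cc1ccc(S(=O)(=O)N2N=C(c3ccc(-n4ccnc4)cc3)CC2c2ccc(N(C)C)cc2)cc1`, carries the change ((4-methylphenyl)sulfonyl in place of (1-methylethenyl)carbonyl on an amine nitrogen in a ring). Going by the values given here, the only step bearing on it is the one from compound 1 to compound 3, which stayed within the scatter, and no measured pair probes a (4-methylphenyl)sulfonyl group. Among the compounds with values here, with every number so far near zero, no step beyond the scatter is expected in this assay; the expected step is a number 3.7 percentage points higher from compound 3 to compound 4 (within the scatter). Compound 4 is therefore estimated at 0%, with a range from -12% to 12%.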

Compound 4, a percentage reported as inhibition, at one concentration (the size of the read-out at that concentration, not a potency): 50.5%
Compound 4: the middle estimate sits 50.5 percentage points below what was measured; the whole stated range lies below it.
By their numbers in this assay, from the lowest: compounds 3, 2 and 1 (each within the scatter of the next); then compound 4.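

In this assay, for the compounds shown here, the substituent on the amine nitrogen in the ring is the first change to move the read-out beyond the scatter, giving a number 54.2 percentage points higher from compound 3 to compound 4 (beyond the scatter) and a number 50.4 percentage points higher from compound 1 to compound 4 (beyond the scatter). The position is therefore not silent on the shared core, as the step from hydrogen to (1-methylethenyl)carbonyl alone had suggested: the outcome depends on which group is placed there, and only (4-methylphenyl)sulfonyl has lifted the number clear of the near-zero level so far. No supporting measurement is available to explain this difference between the groups, so the step stands as an observation only.

The step swaps the linking unit and adds the aromatic ring at once, so the compounds shown do not separate the two: a 4-methylbenzoyl group would keep the ring on a carbonyl, and a plain benzenesulfonyl or a methylsulfonyl on the same core would test the sulfonyl with a smaller or no ring. On these data alone, whether the 4-methyl matters, for example against a 4-methoxy or 4-amino group, also stays open, as does how the effect behaves at other concentrations, since this is a single-concentration reading and not a potency.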